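The compounds below may be only part of what the source reports. "The series", "measured", "known", "first", "only" and "open" are said of these compounds alone.

Of the compounds shown here, three built on the same core have been measured in an in vitro assay on SH-EP1 cells for displacement of a labelled ligand from Neuronal acetylcholine receptor; alpha4/beta2 (Homo sapiens); a higher number here means a weaker inhibitor, a lower number a stronger inhibitor. Compound 1 `Fc1ccc(C2=CC3CNCC(C2)C3)cn1` gives 0.4 nM in this assay. Compound 3 `C1=C(c2cccnc2)C[C@@H]2CNC[C@H]1C2` gives 0.1 nM in this assay. Compound 2 `Clc1ccc(Oc2cncc(C3=CC4CNCC(C3)C4)c2)cc1` gives 1.9 nM in this assay, the highest of the three numbers, so among what has been measured it is the weakest binder, and its distance from compound 1 as well as from compound 3 lies beyond the usual scatter.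

Compound 4 `Clc1ccccc1Oc1cncc(C2=CC3CNCC(C2)C3)c1` has not yet been measured in this assay. It contains the same atoms as compound 2, joined differently: 2-chlorophenyl in place of 4-chlorophenyl on an oxygen on an aromatic ring. Within the data shown here, no measured pair of compounds shows what this kind of rearrangement does, so there is no measured step to lean on. Such a change is expected to move the number only a little, if at all, and the expected step is a 1.6-fold higher number from compound 2 to compound 4 (0.20 log units; within the scatter), within or close to the scatter. For compound 4 the estimate in this assay is 3 nM, with a range from 1 nM to 10 nM.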

Compound 4, inhibition constant: 0.9 nM
The estimate for compound 4 lay 3.3-fold (0.52 log units) above the measured number; measured number outside the range, below it.
By their numbers in this assay, from the lowest: compound 3; then compound 1; then compound 4; then compound 2.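

With the same atoms kept, 2-chlorophenyl in place of 4-chlorophenyl on an oxygen on an aromatic ring gives a 2.1-fold lower number from compound 2 to compound 4 (0.32 log units; beyond the scatter) in this assay. Among these compounds, this is the first measured pair to isolate this place, and it shows that where the chlorine sits on this ring changes the number, if only modestly, and that the 2-chlorophenyl arrangement costs no binding relative to the 4-chlorophenyl one. Nothing available here explains why the two arrangements differ.

Going by these compounds, it remains open what a phenyl carrying no chlorine would do at this place, and whether a bromine or a methyl group in place of the chlorine would give a step of similar size. A single pair also cannot show whether the same rearrangement would have a similar effect on other compounds.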